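The source may report more compounds than this note shows. Statements on the series, on what has been measured and on what is new or still open speak of the compounds shown alone.

Compound 1 `CC1=C(C(=O)Nc2ccc(Br)cc2)C(c2ccc(Cl)cc2Cl)N=C(SCc2cccc(Cl)c2)N1` and compound 2 `CC1=C(C(=O)Nc2ccc(Br)cc2)C(c2ccc(Cl)cc2Cl)N=C(SCc2ccc(Cl)cc2)N1` share one core and differ in a single place: 4-chlorophenyl in place of 3-chlorophenyl on a saturated chain carbon bound to a sulfur. In a functional assay on the whole organism (artery, strain albino) with Rattus norvegicus as the target, with a stated time of 180 min, at a dose of 10 mg/kg by the oral route (on this read-out higher numbers stand for more inhibition at the one dose given (going by the name of the read-out) and lower numbers for less inhibition), compound 1 gives 11.9%, and compound 2 gives 23.2%; this is a number 11.3 percentage points higher from compound 1 to compound 2 (beyond the scatter). Compound 3 `CC1=C(C(=O)Nc2ccc([N+](=O)[O-])cc2)C(c2cccc([N+](=O)[O-])c2)N=C(SCc2cccc(Cl)c2)N1` rests on a second core; the difference between the two cores is not broken down here. In this assay compound 3 gives 14.9%. Compound 4 `CC1=C(C(=O)Nc2ccc([N+](=O)[O-])cc2)C(c2cccc([N+](=O)[O-])c2)N=C(SCc2ccc(Cl)cc2)N1` has not yet been measured and differs from compound 3 by the same change seen before: 4-chlorophenyl in place of 3-chlorophenyl on a saturated chain carbon bound to a sulfur. Because that change once gave a number 11.3 percentage points higher from compound 1 to compound 2 (beyond the scatter), a step of similar size is expected here, namely a number 11.1 percentage points higher from compound 3 to compound 4 (beyond the scatter). For the measured compounds named here, only one earlier example backs this, and the second core is untested for it, so the range is kept wide. Compound 4 is therefore estimated at 26%, likely between 12% and 40%.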

Compound 4, a percentage reported as inhibition, in the whole organism at one dose (the size of the read-out at that dose, not a potency): 14.9%
For compound 4 the middle estimate is 11.1 percentage points above the measured one; the measured number falls inside the stated range.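

On the second core, in this assay, 4-chlorophenyl in place of 3-chlorophenyl gives no change at the digits printed from compound 3 to compound 4 (within the scatter). Set beside the earlier result, the two steps cannot be told apart with confidence: the same change on two cores in this assay, a number 11.3 percentage points higher (beyond the scatter) from compound 1 to compound 2 and no change at the digits printed (within the scatter) from compound 3 to compound 4, 11.3 percentage points apart, within the scatter of two such steps

The rise on the first core is thus not repeated on the second, yet this does not show that the core decides the outcome, and one pair per core is a thin base for either reading. As far as these compounds go, it remains open how a plain benzyl group, a longer alkyl chain or an amine-bearing chain on the sulfur would read in this assay. The two cores also differ in more than one place, so the part of the core that might matter stays unresolved.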